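The compounds below may be only part of what the source reports. "The series", "measured", "known", "first", "only" and "open" are said of these compounds alone.

Measured so far in an assay on isolated protein for inhibition of protein deacetylase HDAC6 (Homo sapiens), read by fluorescence, with a stated time of 30 min; a lower number here means a stronger inhibitor, a higher number a weaker inhibitor:
compound 1 `COc1cc2c(NCc3ccc(C(=O)NO)cc3)cc(-c3ccc(C)o3)nc2cc1OCCCN1CCCC1` gives 11 nM;
compound 2 `COc1cc2c(NCC3CCC(C(=O)NO)CC3)cc(-c3ccc(C)o3)nc2cc1OCCCN1CCCC1` gives 34 nM;
compound 3 `COc1cc2c(NCC3CCN(c4ccc(C(=O)NO)cc4)CC3)cc(-c3ccc(C)o3)nc2cc1OCCCN1CCCC1` gives 67 nM.

Compound 1 stands at the lowest number of the three, with compound 2 nearest and compound 3 furthest from it. Compound 4 `COc1cc2c(NCc3ccc(-c4ccc(C(=O)NO)cc4)cc3)cc(-c3ccc(C)o3)nc2cc1OCCCN1CCCC1` differs from compound 1 by 4-(hydroxycarbamoyl)phenyl in place of hydroxycarbamoyl on an aromatic carbon. Going by the values given here, no measured step makes the same change. The closest step is a 3.1-fold higher number from compound 1 to compound 2 (0.49 log units; beyond the scatter), where the ring that carries the hydroxycarbamoyl group was exchanged rather than extended. The values of compound 1 and compound 3 show that a larger link between the shared core and the hydroxycarbamoyl group went with a higher number. Compound 4 is therefore expected to give a modestly higher number, a 3.6-fold higher number from compound 1 to compound 4 (0.56 log units; beyond the scatter). The estimate for compound 4 in this assay is 40 nM, with a range from 12 nM to 150 nM.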

Compound 4, half-maximal inhibitory concentration: 127 nM
The estimate for compound 4 lay 3.2-fold (0.50 log units) below the measured number; measured number inside the range.
By their numbers in this assay, from the lowest: compound 1; then compounds 2, 3 and 4 (each within the scatter of the next, the first and the last beyond it).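

In this assay, the step from hydroxycarbamoyl to 4-(hydroxycarbamoyl)phenyl on this aromatic carbon gives a 12-fold higher number from compound 1 to compound 4 (1.06 log units; beyond the scatter) and is large. Unlike the ring exchange in the earlier step, this change keeps the ring of compound 1 and adds a six-membered aromatic ring of carbon only, so this position accepts the extension only at a large cost in potency. No measurement shown here explains the size of this step. As far as these compounds go, whether a two-carbon chain carrying hydroxycarbamoyl on this aromatic carbon, or a carboxylic acid in place of hydroxycarbamoyl, would give a number close to that of compound 1 remains open.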